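The source may report more compounds than this note shows. Statements on the series, on what has been measured and on what is new or still open speak of the compounds shown alone.

Measured so far:
compound 1 `CCCC(=O)c1ccc(OCCCCOc2ccc(F)c(C(=O)O)c2)c(C)c1O` — 87.5%
compound 2 `Cc1c(OCCCCOc2ccc(F)c(C(=O)O)c2)ccc(C(=O)CC(C)(C)C)c1O` — 94.6%

In an assay on HEK293 cells for positive allosteric modulation of metabotropic glutamate receptor 2 (Rattus norvegicus), read by thallium flux, with a stated time of 2.5 min (a higher number here means a larger maximal response, a lower number a smaller maximal response), compound 2 gives 94.6%, nominally the top of the two numbers, while compound 1 gives 87.5%; the step of a number 7.1 percentage points higher from compound 1 to compound 2 (within the scatter) lies within the scatter, so the two are not separated by this assay.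

Compound 3 `CCC(=O)c1ccc(OCCCCOc2ccc(F)c(C(=O)O)c2)c(C)c1O` differs from compound 2 in one place: methyl in place of tert-butyl on a saturated chain carbon bound to a carbonyl carbon. Among the measured compounds shown here, the only measured step bearing on this position is a number 7.1 percentage points higher from compound 1 to compound 2 (within the scatter), which already spans a change at the same saturated chain carbon and stays within the scatter. Going on to methyl has no direct precedent in the series, so no step beyond the scatter is expected; the change is estimated as a number 8.6 percentage points lower from compound 2 to compound 3 (within the scatter), a drift towards the value of compound 1 rather than a real shift. For compound 3 the estimate is 86%, with a range from 72% to 100%.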

Compound 3, largest response reached (reported as percent of maximum), in percent of the reference or control that the assay uses: 66.6%
Compound 3: middle estimate off by 19.4 percentage points, on the high side, outside the stated range (below it).
By their numbers in this assay, from the lowest: compound 3; then compounds 1 and 2 (each within the scatter of the next).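

In this assay, this position proves sensitive to chain length: methyl in place of tert-butyl on the saturated chain carbon bound to a carbonyl carbon gives a number 28 percentage points lower from compound 2 to compound 3 (beyond the scatter), and hydrogen in place of methyl on the saturated chain carbon, two bonds along the chain from a carbonyl carbon, gives a number 20.9 percentage points lower from compound 1 to compound 3 (beyond the scatter). Compound 1 and compound 2 stay within the scatter of each other, so the difference appears only with the propanoyl chain of compound 3, and a single methyl at the chain end is enough to separate compound 1 from compound 3. Nothing on hand gives a reason for this drop.

Still open, on these data alone, is whether the response holds with a longer chain such as hexanoyl or with a cyclohexyl group at this carbon. As far as these compounds go, how an amine on the chain would read is also open.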